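The compounds below may be only part of what the source reports. "The series", "measured", "known", "first", "only" and "open" are said of these compounds alone.

Three compounds built on a shared core were assessed in an ADME assay on HepG2 2.2.15 cells (Homo sapiens) for cytotoxicity; on this read-out lower numbers stand for higher toxicity in this test and higher numbers for lower toxicity in this test. Compound 1 `COCCNc1ncc(C(Oc2ccc3cc(Br)ccc3c2)c2ccc(Cl)cc2)s1` is recorded there without a number, simply as "not toxic" (no number reported). Compound 2 `O=C(Nc1ncc(C(Oc2ccc3cc(Br)ccc3c2)c2ccc(Cl)cc2)s1)c1ccc(Br)cc1` reaches only a limit of this assay, > 50000 nM. Compound 3 `COc1ccc(C(=O)Nc2ncc(C(Oc3ccc4cc(Br)ccc4c3)c3ccc(Br)cc3)s2)cc1` likewise reaches only a limit of this assay, > 50000 nM. Compound 3 therefore stands at a limit, alongside one further value that is also a limit and one entry carrying no number at all, as summed up by the limit of > 50000 nM in this assay, at which 2 of the 3 values shown sit. No two of these compounds differ in a single place, so no measured step can be drawn between any pair of them.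

Compound 4 `COc1ccc(C(=O)Nc2ncc(C(Oc3ccc4cc(Br)ccc4c3)c3ccc(C#N)cc3)s2)cc1` has not yet been measured in this assay. It differs from compound 3 by cyano in place of bromo on an aromatic carbon. With two values sitting at a limit and the third given without a number, these data offer no ground for expecting a rise, and nothing shown points towards a fall either. The step expected a step that the limit leaves unreadable from compound 3 to compound 4 is accordingly none beyond the scatter. Compound 4 is estimated at 60000 nM, within 30000 nM to 150000 nM, and is expected most likely to be reported once more only as a limit.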

Compound 4, half-maximal cytotoxic concentration: "not toxic" (no number reported)
Compound 4 has no reported number here, so the estimate cannot be set against anything.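

Compound 3 stands only at a limit and compound 4 carries no number in this assay, so no step can be read between them. The compounds shown leave open at what concentration, if any, cytotoxicity would appear, and whether the change from 4-bromophenyl to 4-cyanophenyl alters it at all: the limit of > 50000 nM in this assay, at which 2 of the 4 values shown sit.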